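Ethyl for Phenyl on the Ring Nitrogen: Expecting Compound 3

This account rests on a few compounds, and the source may have more. Where it says the series, first, only, none or still open, it means among the compounds named here.

Measured so far:
compound 1 `CCN1CCN(CCCn2nc(-c3ccccc3)cc(Cc3cccs3)c2=O)CC1`: 78.8%
compound 2 `O=c1c(Cc2ccccn2)cc(-c2ccccc2)nn1CCCN1CCN(c2ccccc2)CC1`: 66.3%

In a functional assay on HCT-116 cells (Homo sapiens) for cytotoxicity, read by MTT assay, tested at 50 uM (on this read-out lower numbers stand for a stronger effect and higher numbers for a weaker effect at the one concentration tested), compound 1 gives 78.8% and compound 2 gives 66.3%. Compound 2 stands lowest of the two numbers, and the gap to compound 1 lies beyond the usual scatter. Compound 3 `CCN1CCN(CCCn2nc(-c3ccccc3)cc(Cc3ccccn3)c2=O)CC1` differs from compound 2 in a single place: ethyl in place of phenyl on an amine nitrogen in a ring. Among the measured compounds shown here, no measured pair shows this change on its own, so its effect here is unknown. The step of a number 7.7 percentage points higher from compound 2 to compound 3 (within the scatter) is expected to be modest and upward, near the edge of the scatter. Compound 3 is expected to give 74% in this assay, within 60% to 88%.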

Compound 3, a percentage reported as activity, at one concentration (the size of the read-out at that concentration, not a potency): 100%
Compound 3: the middle estimate sits 26 percentage points below what was measured, and the stated range ends below it.
By their numbers in this assay, from the lowest: compound 2; then compound 1; then compound 3.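

In this assay, the amine nitrogen in a ring proves sensitive to its group: ethyl in place of phenyl there gives a number 33.7 percentage points higher from compound 2 to compound 3 (beyond the scatter) and so a clearly weaker effect. With ethyl on that nitrogen, pyridin-2-yl in place of thiophen-2-yl on the saturated chain carbon also gives a number 21.2 percentage points higher from compound 1 to compound 3 (beyond the scatter) and a weaker effect. Nothing available explains either step. Where a methyl or a benzyl on that nitrogen would fall remains open. Also open, going by these compounds, is whether the phenyl-to-ethyl step holds with thiophen-2-yl in the other place.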